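Difluoromethyl in place of butyl on the olefin carbon

The source may hold more compounds than are shown below. What is called first, only, known or untested is meant among the compounds shown, and "the series" means these compounds.

Measured so far:
Compound 1 `CC/C(=C(/c1ccc(/C=C/C(=O)O)cc1)c1ccc2[nH]ncc2c1)c1ccccc1`: in a functional assay on MCF7 cells (Homo sapiens) for cytotoxicity, read by CellTiter-Glo, with a stated time of 5 days (on this read-out lower numbers stand for stronger inhibition and higher numbers for weaker inhibition), compound 1 gives 7.2 nM.
Compound 2 `CCCC/C(=C(/c1ccc(/C=C/C(=O)O)cc1)c1ccc2[nH]ncc2c1)c1ccccc1`: in this assay compound 2 gives 10 nM.

Compound 2 holds the higher of the two numbers, yet the step of a 1.4-fold higher number from compound 1 to compound 2 (0.14 log units; within the scatter) lies within the scatter. Compound 3 `O=C(O)/C=C/c1ccc(/C(=C(\c2ccccc2)C(F)F)c2ccc3[nH]ncc3c2)cc1` differs from compound 2 by difluoromethyl in place of butyl on a double-bonded chain carbon bound to an aromatic carbon and a double-bonded chain carbon. Among the measured compounds shown here, the only measured step, a 1.4-fold higher number from compound 1 to compound 2 (0.14 log units; within the scatter), changes the same chain but keeps carbon throughout; it bears on compound 3 only loosely and gives no reason to expect a shift beyond the scatter in this assay. Compound 3 is therefore expected near compound 2, a step of a 1.2-fold higher number from compound 2 to compound 3 (0.08 log units; within the scatter), with an estimate of 12 nM and a range from 4 nM to 40 nM.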

Compound 3, half-maximal inhibitory concentration: 14 nM
Estimate against measurement, compound 3: 1.2-fold (0.07 log units) below, within the range that was stated.
By their numbers in this assay, from the lowest: compounds 1, 2 and 3 (each within the scatter of the next).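

In this assay, the exchange of butyl for difluoromethyl on this double-bonded chain carbon gives a 1.4-fold higher number from compound 2 to compound 3 (0.15 log units; within the scatter) and the exchange of ethyl for difluoromethyl gives a 1.9-fold higher number from compound 1 to compound 3 (0.29 log units; within the scatter) on the same carbon. This position therefore carries a fluorine-bearing group as well as the plain carbon chains, with no step beyond the scatter. No available data explain this result.

Open, from the compounds shown here alone, is whether trifluoromethyl, hydroxymethyl or a chain ending in an amine on this carbon would move the number beyond the scatter. So far, no group at this position separates from the others.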